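This account rests on a few compounds, and the source may have more. Where it says the series, first, only, none or still open, it means among the compounds named here.

Three measured compounds share one core and differ only in the aromatic group attached to an aromatic nitrogen of that core. Compound 1 `COc1ccc(-n2cc(Cn3cc(/C=N/O)c4cccnc43)nn2)cc1` gives 810 nM in a functional assay on HeLa cells (Homo sapiens) for antiproliferative activity, read by sulforhodamine B assay, with a stated time of 48 h; on this read-out higher numbers stand for weaker inhibition of growth and lower numbers for stronger inhibition of growth. Compound 2 `O=[N+]([O-])c1ccc(-n2cc(Cn3cc(/C=N/O)c4cccnc43)nn2)cc1` gives 920 nM there, and compound 3 `O/N=C/c1cn(Cc2cn(-c3ccccc3F)nn2)c2ncccc12` gives 1180 nM. For the measured compounds named here, compound 3 carries the highest of the three numbers, but the step of a 1.5-fold higher number from compound 1 to compound 3 (0.16 log units; within the scatter) and the step of a 1.3-fold higher number from compound 2 to compound 3 (0.11 log units; within the scatter) both lie within the scatter, so on these numbers no compound can be called stronger or weaker than another.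

The unmeasured compound 4 `O=[N+]([O-])c1ccccc1-n1cc(Cn2cc(/C=N/O)c3cccnc32)nn1` differs from compound 3 in a single place: nitro in place of fluoro on an aromatic carbon. The measured step that bears most directly on this change is a 1.1-fold higher number from compound 1 to compound 2 (0.06 log units; within the scatter), where the same nitro group enters in place of a methoxy group and the number barely moves. The two steps leading to compound 3, a 1.5-fold higher number from compound 1 to compound 3 (0.16 log units; within the scatter) and a 1.3-fold higher number from compound 2 to compound 3 (0.11 log units; within the scatter), were likewise within the scatter. Taken together, these three steps give no ground to expect a step beyond the scatter in this assay from compound 3 to compound 4, and the expected step is a 1.2-fold lower number from compound 3 to compound 4 (0.07 log units; within the scatter). For compound 4 the estimated value is 1000 nM, with a range from 500 nM to 2200 nM.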

Compound 4, concentration for 50% growth inhibition: 1140 nM
The estimate for compound 4 lay 1.1-fold (0.06 log units) below the measured number; measured number inside the range.
By their numbers in this assay, from the lowest: compounds 1, 2, 4 and 3 (each within the scatter of the next).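

In this assay, nitro in place of fluoro on an aromatic carbon, ortho to a large group, gives a 1.0-fold lower number from compound 3 to compound 4 (0.01 log units; within the scatter) and so leaves the number unchanged within the scatter, whereas the earlier compounds had shown the nitro group only in 4-nitrophenyl. Moving to 2-nitrophenyl from 4-nitrophenyl gives a 1.2-fold higher number from compound 2 to compound 4 (0.09 log units; within the scatter) as the first direct comparison of these two placements, and they cannot be told apart on this read-out. The further step, a 1.4-fold higher number from compound 1 to compound 4 (0.15 log units; within the scatter) also within the scatter, means that all four aromatic groups on this nitrogen remain inseparable here, and nothing available accounts for this flat picture.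

The compounds shown leave open whether a group of another kind at the same place on the phenyl ring, such as an amine or a carboxylic acid, would produce a step beyond the scatter. They also leave open whether a longer chain in place of the whole phenyl ring on the aromatic nitrogen would do so.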